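Triazole-linked thiosugar nucleosides: cytotoxicity working notes

This account rests on a few compounds, and the source may have more. Where it says the series, first, only, none or still open, it means among the compounds named here.

Measured so far:
compound 1 `CCS[C@@H]1[C@H](SCC)[C@@H](Cn2cc(-c3ccc(C)cc3)nn2)O[C@H]1n1ccc(=O)[nH]c1=O` — >= 100000 nM
compound 2 `CCS[C@@H]1[C@H](SCC)[C@@H](Cn2cc(-c3ccccc3)nn2)O[C@H]1n1cc(C)c(=O)[nH]c1=O` — "not determined" (no result reported)
compound 3 `CCS[C@@H]1[C@H](SCC)[C@@H](Cn2cc(-c3ccccc3C(F)(F)F)nn2)O[C@H]1n1cc(C)c(=O)[nH]c1=O` — 50600 nM

Within the data shown here, in a functional assay on LAC cells (Homo sapiens) for cytotoxicity, read by MTT assay, with a stated time of 72 h (on this read-out higher numbers stand for an effect only at larger amounts of compound and lower numbers for an effect already at smaller amounts), compound 3 gives 50600 nM, the only single number in the set. Compound 1 sits at a limit of this assay, >= 100000 nM, as noted in the limit of >= 100000 nM in this assay, at which 1 of the 3 values shown sits. For compound 2 the result is "not determined" (no result reported).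

Compound 4 `CCS[C@@H]1[C@H](SCC)[C@@H](Cn2cc(-c3ccc(C)cc3)nn2)O[C@H]1n1cc(C)c(=O)[nH]c1=O` is not yet measured. Change from compound 3: 4-methylphenyl in place of 2-(trifluoromethyl)phenyl on an aromatic carbon. Among the measured compounds shown here, no measured pair covers this change directly; compound 1, which also carries 4-methylphenyl, is known only by its limit. The expected step in this assay is small and toward weaker activity, likely within or just beyond the scatter, written as a 1.8-fold higher number from compound 3 to compound 4 (0.25 log units; within the scatter). Compound 4 is estimated at 90000 nM, range 40000 nM to 200000 nM.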

Compound 4, half-maximal effective concentration: >= 100000 nM
Compound 4: no number, only a limit (the forecaster's own chance of this, stated with the estimate: 55%); middle value at least 1.1-fold (0.04 log units) away from the limit.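

With 4-methylphenyl in place of 2-(trifluoromethyl)phenyl on this aromatic carbon, the series gives its first step at this position: an at least 1.9-fold higher number from compound 3 to compound 4 (0.29 log units; that floor lies within the scatter). In this assay compound 4 gives a limit and not a number: the limit of >= 100000 nM in this assay, at which 2 of the 4 values shown sit. The step for methyl in place of hydrogen on an aromatic carbon cannot be read, as compound 1 and compound 4 both stand at limits.

The change alters both the group and its place on the phenyl ring, and the compounds shown do not separate the two. Also open, on these data alone, is whether an amine or a carboxylic acid on that phenyl ring would give a single number in this assay.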